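Extending the chain on the shared core of compound 1

A few compounds are considered here, and "the series" means these few. Any claim that something is new, unique, unknown or untested is made for them only; others in the source may bear on it.

Compound 1 has the structure `Cc1nnc(SCc2ccccc2)n1N1C(=O)c2ccccc2C1=O`. In a functional assay on PC-3M cells (Homo sapiens) for cytotoxicity, read by MTT assay, with a stated time of 48 h (on this read-out lower numbers stand for stronger inhibition and higher numbers for weaker inhibition), compound 1 gives > 200000 nM, and this value is a limit of the assay rather than a number. Among the measured compounds shown here, compound 2, with the structure `Cc1nnc(SCc2ccccc2Cl)n1N1C(=O)c2ccccc2C1=O`, is the one measured partner of compound 1 that differs in a single place. In this assay compound 2 gives > 200000 nM, which is again a limit and not a number. Between them lies a step that the two limits leave unreadable from compound 1 to compound 2, and the two limits leave its size unreadable. For the measured compounds named here, the only evidence here is the limit of > 200000 nM in this assay, at which 2 of the 2 values shown sit, so nothing measured tells how far either compound sits beyond it.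

Compound 3 has the structure `CCCc1nnc(SCc2ccccc2)n1N1C(=O)c2ccccc2C1=O`. It differs from compound 1 by ethyl in place of hydrogen on a saturated chain carbon bound to an aromatic carbon. Going by the values given here, no measured step concerns a change at this place, and the one step that is known has no readable size. The expected step that the limit leaves unreadable from compound 1 to compound 3 is therefore not a change beyond the scatter, with a limit again the likely outcome. Compound 3 is estimated at 250000 nM, within the range from 100000 nM to 1000000 nM.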

Compound 3, half-maximal inhibitory concentration: > 200000 nM
Compound 3: a limit, no number; the forecaster's own chance of this, stated with the estimate: 80%; the middle value does not contradict the limit.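

In this assay compound 3 gives > 200000 nM, which is a limit and not a number, so the step between compound 1 and compound 3 cannot be read. What stays open is how far compound 1, compound 2 and compound 3 each lie beyond that shared value, and whether ethyl in place of hydrogen changes anything: the limit of > 200000 nM in this assay, at which 3 of the 3 values shown sit.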